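The source may report more compounds than this note shows. Statements on the series, on what has been measured and on what is new or still open speak of the compounds shown alone.

Measured in an ADME assay on HepG2 cells (Homo sapiens) for cytotoxicity, read by luminescence, CellTiter-Glo and ATP content, with a stated time of 72 h (a higher number here means that more compound is needed for the effect, a lower number that less compound is needed), so far:
compound 1 `CC(C)CCc1ccc2c(NCCCNCc3ccco3)ccnc2c1`: 11200 nM
compound 2 `CCC(CC)c1ccc2c(NCCCNCc3ccco3)ccnc2c1`: 6760 nM

Among the measured compounds shown here, compound 2 has the lower of the two numbers, but the only step to it lies within the scatter: a 1.7-fold lower number from compound 1 to compound 2 (0.22 log units; within the scatter). Compound 3 `COc1ccc(Oc2ccc3c(NCCCNCc4ccco4)ccnc3c2)cc1` differs from compound 2 at one place: 4-methoxyphenoxy in place of pentan-3-yl on an aromatic carbon. For the measured compounds named here, no measured step exchanges pentan-3-yl for 4-methoxyphenoxy, and the single step measured is small, so no direction beyond the scatter is expected in this assay. The expected step is a 1.0-fold lower number from compound 2 to compound 3 (0.02 log units; within the scatter). Compound 3 is therefore estimated at 6500 nM. The expected range for compound 3 runs from 2000 nM to 20000 nM.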

Compound 3, half-maximal effective concentration: 5300 nM
Compound 3: middle estimate off by 1.2-fold (0.09 log units), on the high side; low and high end bracket the measured number.
By their numbers in this assay, from the lowest: compounds 3, 2 and 1 (each within the scatter of the next, the first and the last beyond it).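

In this assay, this aromatic carbon carries 4-methoxyphenoxy, which brings a six-membered aromatic ring, with a number close to that of the ringless pentan-3-yl (a 1.3-fold lower number from compound 2 to compound 3 (0.11 log units; within the scatter)). Against isopentyl, the same group gives the first step here beyond the scatter, though a modest one (a 2.1-fold lower number from compound 1 to compound 3 (0.32 log units; beyond the scatter)). Nothing available explains either step. Whether the methoxy matters remains open, since plain phenoxy is not among these compounds. An amine or a carboxylic acid at this position might also shift the number further, or not at all.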